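Swapping a furan for a phenoxy on the sulfonamide aryl

This account rests on a few compounds, and the source may have more. Where it says the series, first, only, none or still open, it means among the compounds named here.

Two compounds share a core and differ only in the group on the sulfonamide aryl ring. Compound 1 `COc1ccc(N2C[C@@H](C)N[C@@H](C)C2)cc1NS(=O)(=O)c1ccc(-n2cccn2)cc1` carries a pyrazolyl group and in a functional assay for agonist activity at growth hormone secretagogue receptor type 1 (Homo sapiens), read by FLIPR (a higher number here means that more compound is needed for the effect, a lower number that less compound is needed), compound 1 gives 15.9 nM. Compound 2 `COc1ccc(N2C[C@@H](C)N[C@@H](C)C2)cc1NS(=O)(=O)c1ccc(-c2ccc(C)o2)cc1` carries a 5-methylfuran-2-yl group; in this assay compound 2 gives 0.794 nM, the lowest of the two, with a 20-fold lower number from compound 1 to compound 2 (1.30 log units; beyond the scatter). Compound 3 `COc1ccc(N2C[C@@H](C)N[C@@H](C)C2)cc1NS(=O)(=O)c1ccc(Oc2ccccc2)cc1` makes a new change: phenoxy in place of 5-methylfuran-2-yl on an aromatic carbon. Among the measured compounds shown here, that earlier step shows this position is sensitive, but no measured pair covers a phenoxy, so compound 3 is estimated at 3 nM, between 0.5 nM and 20 nM, meaning an expected 3.8-fold higher number from compound 2 to compound 3 (0.58 log units; beyond the scatter).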

Compound 3, half-maximal effective concentration: 63.1 nM
Compound 3: middle estimate off by 21-fold (1.32 log units), on the low side; measured number above the stated range.
By their numbers in this assay, from the lowest: compound 2; then compound 1; then compound 3.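

Phenoxy turns out to be the poorest of the three groups at this position in this assay: it brings a 79-fold higher number from compound 2 to compound 3 (1.90 log units; beyond the scatter) and also a 4.0-fold higher number from compound 1 to compound 3 (0.60 log units; beyond the scatter). The position therefore does more than favour 5-methylfuran-2-yl over 1H-pyrazol-1-yl, since a third aromatic group can lie well behind both. Nothing measured here explains this order.

The compounds shown leave open how a phenyl ring joined directly to the sulfonamide aryl ring would compare with phenoxy. They also leave open how an amine would fare at this position.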